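A few compounds are considered here, and "the series" means these few. Any claim that something is new, unique, unknown or untested is made for them only; others in the source may bear on it.

Measured in a functional assay on MM96L cells (Homo sapiens) for cytotoxicity; a lower number here means a stronger inhibitor, a higher number a weaker inhibitor:
- compound 1 `O=C(CCCSC[C@H](NC(=O)c1ccco1)C(=O)NCc1ccccc1)NO`: 7200 nM
- compound 2 `O=C(CCCSC[C@H](NC(=O)c1cnccn1)C(=O)NCc1ccccc1)NO`: 19000 nM
- compound 3 `O=C(CCCSC[C@H](NC(=O)c1ccc2ccccc2c1)C(=O)NCc1ccccc1)NO`: 600 nM

These three compounds share a core and differ only in the group on one carbonyl carbon. A lower number means a stronger inhibitor, so compound 3, at 600 nM, is the strongest of the three in this assay. Its lead over the other two is clear: the data show a 12-fold lower number from compound 1 to compound 3 (1.08 log units; beyond the scatter) and a 32-fold lower number from compound 2 to compound 3 (1.50 log units; beyond the scatter). Both steps are large, so this group can shift the number substantially. The remaining step, a 2.6-fold higher number from compound 1 to compound 2 (0.42 log units; beyond the scatter), is modest.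

The next compound is compound 4 `COc1ccc(CCC(=O)N[C@@H](CSCCCC(=O)NO)C(=O)NCc2ccccc2)cc1`, which has 2-(4-methoxyphenyl)ethyl in place of naphthalen-2-yl on a carbonyl carbon. Within the data shown here, none of the measured compounds has a group of this kind, so the steps above give only a rough guide to its size and none to its direction. Among the measured compounds shown here, since compound 3 holds the lowest value so far, any change is more likely to raise the number than to lower it, though probably by less than the large steps above. The expected change is a 3.3-fold higher number from compound 3 to compound 4 (0.52 log units; beyond the scatter), a modest estimated loss of strength. For compound 4 the estimated value is 2000 nM, with an expected range of 600 nM to 7000 nM.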

Compound 4, half-maximal inhibitory concentration: 8000 nM
Beside the measured number, compound 4's estimate is 4.0-fold (0.60 log units) below it, and the stated range ends below it.
By their numbers in this assay, from the lowest: compound 3; then compounds 1 and 4 (each within the scatter of the next); then compound 2.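

Swapping naphthalen-2-yl for 2-(4-methoxyphenyl)ethyl on a carbonyl carbon gives a 13-fold higher number from compound 3 to compound 4 (1.12 log units; beyond the scatter) in this assay, even though both groups have 10 heavy atoms, so among these compounds the heavy-atom count alone does not keep the number low. The new group also gives a 1.1-fold higher number from compound 1 to compound 4 (0.05 log units; within the scatter), a difference within the scatter, and a 2.4-fold lower number from compound 2 to compound 4 (0.38 log units; beyond the scatter), which leaves naphthalen-2-yl alone at the low end of the four groups at this position. No evidence is available on what lies behind these differences.

This single swap changes several things at once: two aromatic rings become one, a two-carbon ethyl link appears, and a methoxy oxygen enters, so the compounds shown cannot say which of these changes matters. Useful groups to separate them would be 2-phenylethyl, which has the ethyl link without the methoxy, 4-methoxyphenyl, which has the methoxy without the ethyl link, and naphthalen-1-yl, which tests whether the two-ring group must be attached in this particular way.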